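Swapping a Five-Membered Ring on a Deubiquitinase Inhibitor

The compounds below may be only part of what the source reports. "The series", "measured", "known", "first", "only" and "open" are said of these compounds alone.

Compound 2 `Cn1nc2c(=O)n(CC3(O)CCN(Cc4ccc(-c5ccc[nH]5)cc4Cl)CC3)cnc2c1-c1ccc(CN)cc1` was tested in an assay on isolated protein for inhibition of ubiquitin carboxyl-terminal hydrolase 7 (Homo sapiens), with stated times of 30 min and 2 h (on this read-out higher numbers stand for weaker inhibition and lower numbers for stronger inhibition), where compound 2 gives 193 nM. Among the three measured compounds this is the highest number, but the others lie close: compound 1 `Cn1nc2c(=O)n(CC3(O)CCN(Cc4ccc(-c5n[nH]c(=O)o5)cc4Cl)CC3)cnc2c1-c1ccc(CN)cc1` gives 171 nM and compound 3 `Cc1ccc(-c2ccc(CN3CCC(O)(Cn4cnc5c(-c6ccc(CN)cc6)n(C)nc5c4=O)CC3)c(Cl)c2)s1` gives 101 nM. The step of a 1.1-fold higher number from compound 1 to compound 2 (0.05 log units; within the scatter) and the step of a 1.9-fold lower number from compound 2 to compound 3 (0.28 log units; within the scatter) both stay within the scatter, as does the step of a 1.7-fold lower number from compound 1 to compound 3 (0.23 log units; within the scatter).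

Compound 4 `Cn1nc2c(=O)n(CC3(O)CCN(Cc4ccc(-c5ccco5)cc4Cl)CC3)cnc2c1-c1ccc(CN)cc1` differs from compound 2 in one place: furan-2-yl in place of 1H-pyrrol-2-yl on an aromatic carbon. The ring that changes sits on an aromatic carbon of a six-membered aromatic ring of carbon only, meta to a chloro group and para to a large group.

For the measured compounds named here, the steps that bear on this change are the two that exchange one five-membered aromatic ring for another on that aromatic carbon: the ring with three hetero atoms giving way to 1H-pyrrol-2-yl, and 1H-pyrrol-2-yl giving way to 5-methylthiophen-2-yl. Neither moved the number beyond the scatter. Furan-2-yl is another five-membered aromatic ring with one hetero atom, so no step beyond the scatter is expected, a 1.1-fold lower number from compound 2 to compound 4 (0.03 log units; within the scatter). Compound 4 is therefore estimated at 180 nM, with a range from 90 nM to 360 nM.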

Compound 4, half-maximal inhibitory concentration: 18.1 nM
Compound 4: the middle estimate sits 9.9-fold (1.00 log units) above what was measured, and the stated range ends above it.
By their numbers in this assay, from the lowest: compound 4; then compounds 3, 1 and 2 (each within the scatter of the next).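

The position proves not to be indifferent to the five-membered ring it carries: the earlier exchanges in this assay all stayed within the scatter, whereas furan-2-yl stands apart from each of the other three rings, with an 11-fold lower number from compound 2 to compound 4 (1.03 log units; beyond the scatter), a 5.6-fold lower number from compound 3 to compound 4 (0.75 log units; beyond the scatter) and a 9.4-fold lower number from compound 1 to compound 4 (0.98 log units; beyond the scatter), which makes compound 4 the strongest inhibitor of the four. The clearest of these steps is the one from 1H-pyrrol-2-yl, as the two groups have the same number of heavy atoms and the same ring type, and differ in one ring atom, nitrogen against oxygen, and in their counts of hydrogen-bond donors and acceptors. Nothing measured here says why this one ring stands apart.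

Compound 3 differs from compound 4 in both its ring sulfur and its methyl, so the compounds shown leave open which of these two differences carries that step, a question that 5-methylfuran-2-yl or thiophen-2-yl on the same aromatic carbon would separate. Also open, as far as these compounds go, is whether the ring oxygen must lie as it does in furan-2-yl, or whether furan-3-yl or oxazol-2-yl would give a similar number.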